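From 1H-indol-5-yl to 4-aminophenyl on a shared core

The source may hold more compounds than are shown below. What is called first, only, known or untested is meant among the compounds shown, and "the series" means these compounds.

In a functional assay on A549 cells (Homo sapiens) for inhibition, read by MTT assay, with a stated time of 48 h (on this read-out lower numbers stand for stronger inhibition and higher numbers for weaker inhibition), compound 1 (`COc1cc(-c2nccn3cc(-c4ccc(F)cc4)nc23)cc(OC)c1OC`) gives 137 nM and compound 2 (`COc1cc(-c2nccn3cc(-c4ccc5[nH]ccc5c4)nc23)cc(OC)c1OC`) gives 154 nM. Among the measured compounds shown here, these are the only two numbers so far, and they lie within the usual scatter of each other, so compound 2 cannot be told apart from compound 1. Next comes compound 3 (`COc1cc(-c2nccn3cc(-c4ccc(N)cc4)nc23)cc(OC)c1OC`), in which 4-aminophenyl takes the place of 1H-indol-5-yl on an aromatic carbon of a five-membered aromatic ring with 2 nitrogen: 4-aminophenyl in place of 1H-indol-5-yl on an aromatic carbon. For the measured compounds named here, the only measured step at this place is a 1.1-fold higher number from compound 1 to compound 2 (0.05 log units; within the scatter). In that step, 1H-indol-5-yl replaced 4-fluorophenyl and the numbers stayed within the scatter. A single step is thin evidence, but it shows two different groups at this place giving matching numbers. No shift beyond the scatter is therefore expected in this assay, and the data favour no direction. The expected step is a 1.0-fold lower number from compound 2 to compound 3 (0.01 log units; within the scatter). The estimate for compound 3 is 150 nM, with an expected range of 50 nM to 450 nM.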

Compound 3, half-maximal inhibitory concentration: 287 nM
The estimate for compound 3 lay 1.9-fold (0.28 log units) below the measured number, within the range that was stated.
By their numbers in this assay, from the lowest: compounds 1, 2 and 3 (each within the scatter of the next, the first and the last beyond it).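

In this assay, replacing 1H-indol-5-yl with 4-aminophenyl gives a 1.9-fold higher number from compound 2 to compound 3 (0.27 log units; within the scatter), so this change on its own cannot be told apart from the ordinary spread of repeated measurements. Among the compounds shown here, the more telling comparison is amino in place of fluoro on the same phenyl ring, which gives a 2.1-fold higher number from compound 1 to compound 3 (0.32 log units; beyond the scatter): this is the first step at this position to pass beyond the scatter, if only modestly, and it shows that the group here can move the number, with compound 3 weaker than compound 1, whereas the earlier pair alone showed only two different groups giving matching numbers. No measurement at hand accounts for this shift, so the data record the size of the step without explaining it.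

The compounds shown leave open how a hydroxyl group, a dimethylamino group or a carboxylic acid would read in place of the amino group of compound 3, and so whether the small loss belongs to the amino group specifically. They also leave open whether the step from fluoro to amino would hold on a different core or in other cells.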